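Swapping the Amide Substituent Between Two Compounds

This account rests on a few compounds, and the source may have more. Where it says the series, first, only, none or still open, it means among the compounds named here.

Measured so far:
compound 1 `CN(CCCn1ccnc1)C(=O)[C@@H]1CCCN1c1nccc(Nc2ccccc2)n1`: 0%
compound 2 `COC[C@@H]1CCCN1C(=O)C1CCCN1c1cc(Nc2cccc(Br)c2)ncn1`: 0%

In an assay on isolated protein for inhibition of RAC-alpha serine/threonine-protein kinase (Homo sapiens), read by HTRF, tested at 10 uM (a higher number here means more inhibition at the concentration tested (going by the name of the read-out), a lower number less inhibition), compound 1 gives 0% and stands level with compound 2, which gives 0%; the two lie within the scatter of each other. Compound 3 `COC[C@@H]1CCCN1C(=O)[C@@H]1CCCN1c1nccc(Nc2ccccc2)n1` differs from compound 1 in one place: 2-(methoxymethyl)pyrrolidin-1-yl in place of (3-(1H-imidazol-1-yl)propyl)(methyl)amino on a carbonyl carbon. Among the measured compounds shown here, no step between measured compounds is known here, so nothing points to a shift beyond the scatter. The entering group already appears in compound 2, which shows no inhibition at 0%. Compound 3 is therefore expected at 2%, in a range from 0% to 12%. The expected step of a number 2 percentage points higher from compound 1 to compound 3 (within the scatter) is none beyond the scatter.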

Compound 3, a percentage reported as inhibition, at one concentration (the size of the read-out at that concentration, not a potency): 0%
Compound 3: middle estimate off by 2 percentage points, on the high side; low and high end bracket the measured number.
By their numbers in this assay, from the lowest: compounds 1, 2 and 3 (each within the scatter of the next).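

Replacing (3-(1H-imidazol-1-yl)propyl)(methyl)amino with 2-(methoxymethyl)pyrrolidin-1-yl on a carbonyl carbon gives no change at the digits printed from compound 1 to compound 3 (within the scatter) in this assay and so shows that this swap does not bring out inhibition on the core of compound 1. With neither compound showing any inhibition, the step cannot rank the two groups against each other. No measurement available here bears on why this is so.

On these data alone, whether a morpholin-4-yl or dimethylamino group on the same carbonyl carbon would give any inhibition stays open. So does whether any group here would count on a core that shows inhibition.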